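A few compounds are considered here, and "the series" means these few. Any claim that something is new, unique, unknown or untested is made for them only; others in the source may bear on it.

In a functional assay on LNCaP cells (Homo sapiens) for antiproliferative activity, read by propidium iodide staining, with a stated time of 96 h (on this read-out lower numbers stand for stronger inhibition and higher numbers for weaker inhibition), compound 1 `CC(O)(CSc1ccccc1C(F)(F)F)C(=O)Nc1ccc(S(F)(F)(F)(F)F)cc1` reads 12300 nM and compound 2 `CC(O)(CSc1ccccc1OC(F)(F)F)C(=O)Nc1ccc(S(F)(F)(F)(F)F)cc1` reads 10600 nM while compound 3 `CC(O)(CSc1ccc(S(F)(F)(F)(F)F)cc1)C(=O)Nc1cccc(S(F)(F)(F)(F)F)c1` reads 12700 nM so compound 3 sits level with both, within the scatter. Compound 4 `CC(O)(CSc1ccc(F)cc1)C(=O)Nc1cccc(S(F)(F)(F)(F)F)c1` differs from compound 3 by one fluorine atom in place of a group of 6 heavy atoms (5 fluorine, 1 sulfur; no ring), on an aromatic carbon and by nothing else. Among the measured compounds shown here, no measured pair shows this exchange. The nearest evidence is a swap of other groups, a 1.2-fold lower number from compound 1 to compound 2 (0.06 log units; within the scatter) and that step is small, so it offers only weak guidance for so large a change. The expected step is a 1.1-fold higher number from compound 3 to compound 4 (0.04 log units; within the scatter) and it has no firm direction. Compound 4 is estimated at 14000 nM with an expected range from 6000 nM to 35000 nM in this assay as a deliberately wide guess.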

Compound 4, half-maximal inhibitory concentration: 26900 nM
The estimate for compound 4 lay 1.9-fold (0.28 log units) below the measured number; low and high end bracket the measured number.
By their numbers in this assay, from the lowest: compounds 2, 1 and 3 (each within the scatter of the next); then compound 4.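

In this assay, among the compounds shown here, fluoro in place of the group of 6 heavy atoms (5 fluorine, 1 sulfur) on this aromatic carbon gives a 2.1-fold higher number from compound 3 to compound 4 (0.33 log units; beyond the scatter) and is the first step here beyond the scatter. At this position, then, the larger group goes with the lower number, though the step is modest and rests on a single pair. No measurement here bears on the reason for this step.

As far as these compounds go, what an amine, a carboxylic acid or a longer chain would do on this carbon stays open. Also open, from the compounds shown here alone, is whether the same exchange would give a similar step elsewhere on the shared core.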